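From compound 3 to compound 4: one group exchanged

The source may report more compounds than this note shows. Statements on the series, on what has been measured and on what is new or still open speak of the compounds shown alone.

Compound 1 `COc1ccc(Nc2ncc(C(F)(F)F)c(N3Cc4cccc(N(C)S(C)(=O)=O)c4C3)n2)cc1C(F)(F)F` gives > 30000 nM (a limit)
Compound 2 `COc1cc(Nc2ncc(C(F)(F)F)c(N3Cc4cccc(N(C)S(C)(=O)=O)c4C3)n2)c(OC)cc1Cl` gives 25600 nM
Compound 3 `CN(c1cccc2c1CN(c1nc(Nc3ccc(C(F)(F)F)cc3)ncc1C(F)(F)F)C2)S(C)(=O)=O` gives > 30000 nM (a limit)

All of these values come from a functional assay on HepG2 cells (Homo sapiens) for antiproliferative activity, read by spectrophotometry, with a stated time of 2 days (on this read-out lower numbers stand for stronger inhibition of growth and higher numbers for weaker inhibition of growth), and the three compounds differ only in one group on the shared core. Compound 3 stands at > 30000 nM, which is a limit of the assay and not a number. The set as a whole shows (the limit of > 30000 nM in this assay, at which 2 of the 3 values shown sit), so it offers little to measure against.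

Compound 4 `Cc1ccc(Nc2ncc(C(F)(F)F)c(N3Cc4cccc(N(C)S(C)(=O)=O)c4C3)n2)c(C)c1` changes that same group: 2,4-dimethylphenyl in place of 4-(trifluoromethyl)phenyl on a nitrogen on an aromatic ring. In words, 2,4-dimethylphenyl replaces 4-(trifluoromethyl)phenyl on a nitrogen on an aromatic ring.

Within the data shown here, no measured step makes this exact exchange, but three alter the same group: an at least 1.1-fold lower number from compound 1 to compound 2 (0.06 log units; that floor lies within the scatter), a step that the two limits leave unreadable from compound 1 to compound 3 and an at least 1.1-fold higher number from compound 2 to compound 3 (0.06 log units; that floor lies within the scatter). None of them is shown to go beyond the scatter, so no step beyond the scatter is expected here, in either direction, in this assay. The estimate means an expected at least 1.0-fold lower number from compound 3 to compound 4 (0.02 log units; that floor lies within the scatter). Compound 4 is expected at 28000 nM, with an estimated range from 14000 nM to 45000 nM.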

Compound 4, concentration for 50% growth inhibition: 19100 nM
Beside the measured number, compound 4's estimate is 1.5-fold (0.17 log units) above it, and the stated range covers the measured number.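

In this assay, the 2,4-dimethylphenyl group on a nitrogen on an aromatic ring gives compound 4 a real number rather than a limit, yet the readings change little: an at least 1.5-fold lower number from compound 3 to compound 4 (0.19 log units; that floor lies within the scatter), and an at least 1.5-fold lower number from compound 1 to compound 4 (0.19 log units; that floor lies within the scatter). Against the other compound with a real number, the step is a 1.3-fold lower number from compound 2 to compound 4 (0.13 log units; within the scatter). So a phenyl group carrying only methyl groups, with no fluorine, chlorine or methoxy, is not shown to differ from the others, and the set still sits largely at one edge of the assay: the limit of > 30000 nM in this assay, at which 2 of the 4 values shown sit.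

Going by these compounds, whether a phenyl group bearing an amine or a carboxylic acid, or a longer alkyl chain in place of the ring, would move the number beyond the scatter remains open. Changes elsewhere on the shared core also remain open.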